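One aryl swap on a shared core, awaiting its readout

This account rests on a few compounds, and the source may have more. Where it says the series, first, only, none or still open, it means among the compounds named here.

Two compounds have so far been tested in a functional assay on SW-620 cells (Homo sapiens) for cytotoxicity, read by sulforhodamine B assay, with a stated time of 48 h, tested at 0.1 uM; a higher number here means a weaker effect of the compound at the concentration tested, a lower number a stronger effect:

Compound 1 `COc1cc(-c2cc(/C=C/C(=O)c3ccc(N)cc3)[nH]n2)cc(OC)c1OC` gives 95%.
Compound 2 `COc1ccc(-c2cc(/C=C/C(=O)c3ccc(OC)c(OC)c3)[nH]n2)cc1` gives 99%.

Compound 1 gives the lower of the two numbers, but compound 2 sits only a few points higher, within the usual scatter, so the two cannot be ordered; both show only a slight effect at this concentration. The two structures differ in more than one place, so nothing can be read from their pair beyond those two values.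

Compound 3 `COc1cc(-c2cc(/C=C/C(=O)c3ccc(Cl)c(Cl)c3)[nH]n2)cc(OC)c1OC` has not been measured. It differs from compound 1 by 3,4-dichlorophenyl in place of 4-aminophenyl on a carbonyl carbon. Going by the values given here, no measured pair shows a change of this kind, so there is no earlier step to lean on.

Given the weak effect of compound 1, the step is expected to stay within the scatter, a number 2 percentage points lower from compound 1 to compound 3 (within the scatter). Compound 3 is therefore estimated at 93%, likely between 78% and 104%.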

Compound 3, a percentage reported as activity, at one concentration (the size of the read-out at that concentration, not a potency): 99%
Compound 3: the middle estimate sits 6 percentage points below what was measured; measured number inside the range.
By their numbers in this assay, from the lowest: compounds 1, 2 and 3 (each within the scatter of the next).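

Going by these compounds alone, this is the first step in the set that alters one place alone: on a carbonyl carbon, 3,4-dichlorophenyl stands in place of 4-aminophenyl, and in this assay that swap gives a number 4 percentage points higher from compound 1 to compound 3 (within the scatter). At this position, then, losing the hydrogen-bond donor and acceptor counted for 4-aminophenyl and gaining two chlorine atoms leaves no readable difference at the concentration tested. No independent measurement is available to help interpret this result.

From the compounds shown here alone, whether a carboxylic acid or a longer chain on that carbonyl carbon would give a number clearly apart from these remains open. Also open, going by these compounds, is whether the swap would matter at a concentration where compound 1 and compound 3 show a stronger effect.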